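This account rests on a few compounds, and the source may have more. Where it says the series, first, only, none or still open, it means among the compounds named here.

Working notes on the series. All members share one core and differ only in the group on a carbon with a double bond to nitrogen. In a functional assay on A549 cells (Homo sapiens) for cytotoxicity, read by MTT assay, with a stated time of 72 h (on this read-out lower numbers stand for stronger inhibition and higher numbers for weaker inhibition), compound 1 `CN(C)CCn1cnnc1-c1cc(Oc2ccc(NC(=O)N/N=C/c3ccc(Cl)cc3Cl)cc2F)ccn1` gives 810 nM; compound 2 `CN(C)CCn1cnnc1-c1cc(Oc2ccc(NC(=O)N/N=C/c3c[nH]c4ccccc34)cc2F)ccn1` gives 820 nM; compound 3 `CN(C)CCn1cnnc1-c1cc(Oc2ccc(NC(=O)N/N=C/c3c(O)ccc4ccccc34)cc2F)ccn1` gives 880 nM, a number that sits inside the scatter with both of the others. Compound 4 `COc1ccc(/C=N/NC(=O)Nc2ccc(Oc3ccnc(-c4nncn4CCN(C)C)c3)c(F)c2)cc1O` differs from compound 3 by 3-hydroxy-4-methoxyphenyl in place of 2-hydroxynaphthalen-1-yl on a carbon with a double bond to nitrogen. Each change already made at this position, a 1.0-fold higher number from compound 1 to compound 2 (0.01 log units; within the scatter), a 1.1-fold higher number from compound 1 to compound 3 (0.04 log units; within the scatter) and a 1.1-fold higher number from compound 2 to compound 3 (0.03 log units; within the scatter), stayed within the scatter, so the new exchange is also expected to give no step beyond the scatter in this assay. The estimated step is therefore a 1.0-fold lower number from compound 3 to compound 4 (0.02 log units; within the scatter). Compound 4 is expected at 850 nM, with a range from 400 nM to 1800 nM.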

Compound 4, half-maximal inhibitory concentration: > 100000 nM
Compound 4 gave a limit, no number; the forecaster's own chance of this, stated with the estimate: 3%; middle value at least 110-fold (2.07 log units) from the limit.
By their numbers in this assay, from the lowest: compounds 1, 2 and 3 (each within the scatter of the next). At a limit, above all of these: compound 4.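

The value of compound 4 in this assay is a limit, not a number: the limit of > 100000 nM in this assay, at which 1 of the 4 values shown sits. This exchange, unlike the earlier ones at this position, gives steps beyond the scatter: an at least 110-fold higher number from compound 3 to compound 4 (2.05 log units; beyond the scatter), an at least 120-fold higher number from compound 2 to compound 4 (2.08 log units; beyond the scatter) and an at least 120-fold higher number from compound 1 to compound 4 (2.09 log units; beyond the scatter). The position on a carbon with a double bond to nitrogen is therefore not indifferent to its group, although 2,4-dichlorophenyl, 1H-indol-3-yl and 2-hydroxynaphthalen-1-yl read alike there.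

As far as these compounds go, it remains open whether the hydroxy or the methoxy group of 3-hydroxy-4-methoxyphenyl goes with this loss. A 4-methoxyphenyl or a 3-hydroxyphenyl group at this place would separate the two.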